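From a Methylimidazolyl to a Dichlorophenyl Sulfonamide

A few compounds are considered here, and "the series" means these few. Any claim that something is new, unique, unknown or untested is made for them only; others in the source may bear on it.

Compound 1 `CC1CCN(C2CCN(S(=O)(=O)c3nccn3C)CC2)CC1` was profiled in an ADME assay on HCT-116 cells (Homo sapiens) for cytotoxicity, read by CellTiter-Glo, with a stated time of 72 h; a lower number here means a stronger inhibitor, a higher number a weaker inhibitor. In this assay compound 1 gives > 10000 nM, which is a limit of the assay rather than a number. Compound 2 `CC(=O)Nc1ccc(S(=O)(=O)N2CCC(N3CCC(C)CC3)CC2)c2ccccc12` carries the same core as compound 1. In this assay compound 2 likewise gives > 10000 nM, again a limit and not a number. Going by the values given here, both results therefore sit at the limit of > 10000 nM in this assay, at which 2 of the 2 values shown sit, and no measured step between compounds is available. Compound 1 thus stands at the limit, with nothing shown to set it apart from compound 2.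

Compound 3 `CC1CCN(C2CCN(S(=O)(=O)c3cc(Cl)cc(Cl)c3)CC2)CC1` has not yet been measured in this assay. It differs from compound 1 in one place: 3,5-dichlorophenyl in place of 1-methyl-1H-imidazol-2-yl on a sulfonyl sulfur. Among the compounds with values here, with both known values at a limit, no step is measured, and in this assay the change is expected to bring no step beyond the scatter, most likely leaving compound 3 at the limit as well, though a modest move toward stronger inhibition cannot be excluded. Compound 3 is estimated at 8000 nM, within 2000 nM to 30000 nM. The estimate for compound 3 amounts to an expected at least 1.2-fold lower number from compound 1 to compound 3 (0.09 log units; that floor lies within the scatter).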

Compound 3, half-maximal inhibitory concentration: > 5000 nM
Compound 3: no number, only a limit; the forecaster's own chance of this, stated with the estimate: 65%; the middle value is on the limit's open side.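

In this assay compound 3 gives > 5000 nM, which is a limit of the assay and not a number. Compound 1 also stands at a limit, so no step can be read between compound 1 and compound 3. The compounds shown leave open whether any group on the sulfonyl sulfur would give a measured number in this assay.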